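The source may hold more compounds than are shown below. What is called first, only, known or untested is meant among the compounds shown, and "the series" means these compounds.

Measured so far in a functional assay on CCRF-CEM cells (Homo sapiens) for inhibition, read by sulforhodamine B assay, with a stated time of 48 h, tested at 10 uM; on this read-out higher numbers stand for a weaker effect at the one concentration tested and lower numbers for a stronger effect:
- compound 1, `COc1cc(Cl)cc(-c2nn(-c3cccc(NC(=O)c4ccc(Cl)c(Cl)c4)c3)cc2-c2ccncc2)c1`, gives 59.2%
- compound 2, `COc1cc(Cl)cc(-c2nn(-c3cccc(NC(=O)c4cccc(C(F)(F)F)c4)c3)cc2-c2ccncc2)c1`, gives 42.3%
- compound 3, `O=C(Nc1cccc(-n2cc(-c3ccncc3)c(-c3cc(O)cc(Cl)c3)n2)c1)c1cc(C(F)(F)F)cc(C(F)(F)F)c1`, gives 26.9%

Compound 3 stands lowest of these three numbers: compound 2 sits a number 16.9 percentage points lower from compound 1 to compound 2 (beyond the scatter), and compound 3 in turn lies beyond the scatter below compound 2 and further still below compound 1. Compound 4, `COc1cc(Cl)cc(-c2nn(-c3cccc(NC(=O)c4cc(C(F)(F)F)cc(C(F)(F)F)c4)c3)cc2-c2ccncc2)c1`, differs from compound 3 by methyl in place of hydrogen on an oxygen on an aromatic ring. Going by the values given here, compound 3 is the only measured compound with a hydroxy group at this place; compounds 1 and 2 carry a methoxy but also differ from compound 3 in the group on the carbonyl carbon, so their values do not isolate this change. Among the compounds with values here, the one measured step, from compound 1 to compound 2, concerns the carbonyl aryl, not the oxygen, and so does not bear directly on the step to compound 4. Within the data shown here, with no step in the data on this change, compound 4 is expected to stay near compound 3, with a number 5.1 percentage points higher from compound 3 to compound 4 (within the scatter) estimated as no step beyond the scatter. The estimate for compound 4 in this assay is 32%, between 18% and 50%.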

Compound 4, a percentage reported as activity, at one concentration (the size of the read-out at that concentration, not a potency): 57.1%
Compound 4: middle estimate off by 25.1 percentage points, on the low side, outside the stated range (above it).
By their numbers in this assay, from the lowest: compound 3; then compound 2; then compounds 4 and 1 (each within the scatter of the next).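

In this assay, replacing hydroxy with methoxy, a change of one methyl on an oxygen on an aromatic ring, gives a number 30.2 percentage points higher from compound 3 to compound 4 (beyond the scatter), a large loss of effect at the one concentration tested, which shows that this position is sensitive to this change. The added trifluoromethyl on an aromatic carbon gives a number 14.8 percentage points higher from compound 2 to compound 4 (beyond the scatter), so with methoxy in place, this extra group goes with a weaker effect rather than a stronger one, and the low number of compound 3 cannot be credited to the carbonyl aryl alone. Nothing available explains the size of either step.

As far as these compounds go, the hydroxy to methoxy change has been read with only one carbonyl aryl, so it remains open whether it holds with the others. From the compounds shown here alone, it is also open how an amine or a longer chain such as ethoxy at this place would compare.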